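The source may report more compounds than this note shows. Statements on the series, on what has been measured and on what is new or still open speak of the compounds shown alone.

Measured so far in a functional assay on BT-549 cells (Homo sapiens) for inhibition, read by sulforhodamine B assay, with a stated time of 48 h; a higher number here means a weaker inhibitor of growth, a lower number a stronger inhibitor of growth:
compound 1 `COc1cc(-c2nn(-c3cccc(NC(=O)Nc4ccc(Cl)c(Cl)c4)c3)cc2-c2ccncc2)ccc1Cl`: 1680 nM
compound 2 `O=C(Nc1cccc(-n2cc(-c3ccncc3)c(-c3ccc(Cl)c(O)c3)n2)c1)Nc1ccc(Cl)c(Cl)c1`: 1700 nM
compound 3 `O=C(Nc1cccc(-n2cc(-c3ccncc3)c(-c3ccc(Cl)c(O)c3)n2)c1)Nc1cc(C(F)(F)F)cc(C(F)(F)F)c1`: 1090 nM

Among these three numbers compound 1 stands second highest; compound 2 lies nearest to it and compound 3 furthest, and both gaps are within the usual scatter, so the three compounds cannot be ranked against one another. For the measured compounds named here, the only step that changes a single place, a 1.0-fold higher number from compound 1 to compound 2 (0.01 log units; within the scatter), swaps a methyl on the aromatic oxygen for a hydrogen and leaves the number where it was.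

Compound 4 `COc1cc(-c2nn(-c3cccc(NC(=O)c4ccccc4)c3)cc2-c2ccncc2)ccc1Cl` is the next compound to be measured. It differs from compound 1 in a different part of the molecule: phenyl in place of (3,4-dichlorophenyl)amino on a carbonyl carbon. This turns the urea into a simple amide and removes a hydrogen-bond donor together with the dichlorinated ring. Going by the values given here, no measured step touches this position. Compound 2 and compound 3 do differ at that ring, but they also differ from compound 1 elsewhere, and their two values sit within the scatter of each other, so they give no direction.

With nothing measured to lean on, the expectation rests on the size of the change alone: a weaker inhibitor is expected, a step of a 3.0-fold higher number from compound 1 to compound 4 (0.47 log units; beyond the scatter). Compound 4 is therefore estimated at 5000 nM, with a range from 1500 nM to 16000 nM.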

Compound 4, concentration for 50% growth inhibition: 1330 nM
For compound 4 the middle estimate is 3.8-fold (0.58 log units) above the measured one; the measured number lies below the stated range.
By their numbers in this assay, from the lowest: compounds 3, 4, 1 and 2 (each within the scatter of the next).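

In this assay, putting phenyl in place of (3,4-dichlorophenyl)amino on the carbonyl carbon gives a 1.3-fold lower number from compound 1 to compound 4 (0.10 log units; within the scatter) and so does not separate the two compounds, even though the urea has become a simple amide. For the compounds shown here, this is the first single-place comparison at this position, and it shows that, for this pair, the ring's two chlorine atoms and the hydrogen-bond donor can both go without a step beyond the scatter. No independent measurement accompanies this result that could explain it.

The compounds shown leave open whether any other group on this carbonyl carbon would give a clear step in either direction, such as a phenyl ring carrying an amine or a carboxylic acid, or a longer carbon chain in place of the ring. They also leave open whether the amide would stay within the scatter of compound 4 with hydrogen in place of the methyl on the aromatic oxygen, the change that separated compound 1 and compound 2 in the urea.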